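Cytotoxicity notes: aryl swap on the benzyl of compound 3

The source may report more compounds than this note shows. Statements on the series, on what has been measured and on what is new or still open speak of the compounds shown alone.

Measured compounds in an ADME assay on A549 cells (Homo sapiens) for cytotoxicity, read by CellTiter-Glo; on this read-out higher numbers stand for lower toxicity in this test and lower numbers for higher toxicity in this test:

compound 1 `Cc1c(Cc2ccccc2)c(=O)oc2cc(OCC(O)CNCCCCCCO)ccc12` gives 40300 nM
compound 2 `Cc1c(Cc2ccccc2)c(=O)oc2cc(OCC(O)CNCc3cccs3)ccc12` gives 87300 nM
compound 3 `Cc1c(Cc2cccc(F)c2)c(=O)oc2cc(OCC(O)CN3CCC(C(N)=O)CC3)ccc12` gives 53300 nM

Compound 3 stands second highest of the three numbers in this assay; its gap to compound 1 and its gap to compound 2 both lie within the scatter, so the three compounds cannot be ordered on this read-out. Among the compounds with values here, the one single-point step measured so far, a 2.2-fold higher number from compound 1 to compound 2 (0.34 log units; beyond the scatter), concerns the group on the saturated chain carbon bound to the amine nitrogen, and it was modest.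

Compound 4 `Cc1c(Cc2ccc(OC(F)(F)F)cc2)c(=O)oc2cc(OCC(O)CN3CCC(C(N)=O)CC3)ccc12` differs from compound 3 at a different place: 4-(trifluoromethoxy)phenyl in place of 3-fluorophenyl on a saturated chain carbon bound to an aromatic carbon. Within the data shown here, no measured pair changes this benzyl aryl, so the step from compound 1 to compound 2 does not bear on it directly; it shows only that a modest change elsewhere in the shared core moved the number by a modest amount. With nothing on the aryl itself to go on, the expectation for compound 4 in this assay is a step no larger than the scatter, in no particular direction, a 1.1-fold lower number from compound 3 to compound 4 (0.03 log units; within the scatter). Compound 4 is therefore estimated near 50000 nM, with an expected range of 20000 nM to 125000 nM, kept wide since a 2.2-fold higher number from compound 1 to compound 2 (0.34 log units; beyond the scatter) concerns a different site.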

Compound 4, half-maximal cytotoxic concentration: 68200 nM
For compound 4 the middle estimate is 1.4-fold (0.13 log units) below the measured one; the measured number falls inside the stated range.
By their numbers in this assay, from the lowest: compounds 1, 3, 4 and 2 (each within the scatter of the next, the first and the last beyond it).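

In this assay, within the data shown here, the step of a 1.3-fold higher number from compound 3 to compound 4 (0.11 log units; within the scatter) is the first measured pair on the benzyl aryl, and it shows that this read-out does not separate 4-(trifluoromethoxy)phenyl from 3-fluorophenyl on the saturated chain carbon bound to an aromatic carbon. The exchange is not a small one on paper, with more heavy atoms entering than leaving and a hydrogen-bond acceptor entering where the leaving group has none, so within this pair neither the added atoms nor the different substitution of the phenyl ring registers beyond the scatter. No measurement on these compounds offers a reason for this outcome.

One pair cannot show how far this tolerance extends, and an amine or a carboxylic acid on this phenyl ring, or a longer chain in place of the benzyl carbon, could read quite differently in this assay from the two neutral aryl groups compared here. Among these compounds, also open is whether 4-(trifluoromethoxy)phenyl would read the same when carried with the amine side chains of compound 1 and compound 2 rather than the one shared by compound 3 and compound 4.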